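Replacing the azepan-1-yl group on the shared core

The compounds below may be only part of what the source reports. "The series", "measured", "known", "first", "only" and "open" are said of these compounds alone.

Compound 1 `CN(c1ccc2cc(NC(=O)CCc3ccc(C(F)(F)F)cc3)ccc2n1)C1CCCCC1`: 18 nM in an assay on isolated protein for displacement of a labelled ligand from melanin-concentrating hormone receptor 1 (Homo sapiens); on this read-out lower numbers stand for stronger inhibition and higher numbers for weaker inhibition
Compound 2 `NC1CCN(c2ccc3cc(NC(=O)CCc4ccc(C(F)(F)F)cc4)ccc3n2)C1`: 12 nM
Compound 3 `O=C(CCc1ccc(C(F)(F)F)cc1)Nc1ccc2nc(N3CCCCCC3)ccc2c1`: 36 nM

Among these three, compound 3 shows the highest number in this assay. The step of a 2.0-fold higher number from compound 1 to compound 3 (0.30 log units; within the scatter) stays within the scatter, while the step of a 3.0-fold higher number from compound 2 to compound 3 (0.48 log units; beyond the scatter) is the only one of the three that goes beyond it; the step of a 1.5-fold lower number from compound 1 to compound 2 (0.18 log units; within the scatter) is again within the scatter. All three measured compounds share the same core and differ only in the amine attached to it, so every step already seen bears on the change now considered.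

Compound 4 `O=C(CCc1ccc(C(F)(F)F)cc1)Nc1ccc2nc(N3CC4CCC3C4)ccc2c1` is built from compound 3 by the change (a group of 7 heavy atoms (6 carbon, 1 nitrogen; one five-membered non-aromatic ring of carbon only, one five-membered non-aromatic ring with 1 hetero atom) in place of a group of 7 heavy atoms (6 carbon, 1 nitrogen; one seven-membered non-aromatic ring with 1 hetero atom), on an aromatic carbon).

The earlier exchanges of one amine for another at this same position moved the number by small amounts, two of them inside the scatter and one modestly beyond it. By that record, replacing azepan-1-yl with another group of the same count of heavy atoms is expected to give at most a modest shift, with no clear direction to favour. The step of a 1.2-fold lower number from compound 3 to compound 4 (0.08 log units; within the scatter) is therefore expected to be small. Compound 4 is estimated to show 30 nM in this assay, within a range from 12 nM to 75 nM.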

Compound 4, half-maximal inhibitory concentration: 1 nM
Estimate against measurement, compound 4: 30-fold (1.48 log units) above; the whole stated range lies above it.
By their numbers in this assay, from the lowest: compound 4; then compounds 2, 1 and 3 (each within the scatter of the next, the first and the last beyond it).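

In this assay, this position proves far more sensitive than the earlier amines suggested. In a 36-fold lower number from compound 3 to compound 4 (1.56 log units; beyond the scatter), the count of heavy atoms, the carbon and nitrogen make-up, the hydrogen-bond counts and the net charge all stay the same, so these counts alone do not decide the result; what changes is the ring make-up, with one seven-membered ring leaving and two five-membered rings entering. The gain is not limited to the comparison with azepan-1-yl, as a 12-fold lower number from compound 2 to compound 4 (1.08 log units; beyond the scatter) and an 18-fold lower number from compound 1 to compound 4 (1.26 log units; beyond the scatter) are also large, and compound 4 is the strongest of the four compounds in this assay.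

No measurement shown here explains why this two-ring group does so much better than the other amines. On these data alone, it also remains open whether a single-ring amine such as piperidin-1-yl would fall closer to compound 3 or compound 4, and whether adding an amino group to the two-ring group, as carried by the ring of compound 2, would keep the low number.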